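Shifting the Halogen Around the Benzyl Ring

The source may report more compounds than this note shows. Statements on the series, on what has been measured and on what is new or still open speak of the compounds shown alone.

Of the compounds shown here, three built on one shared core have been tested in a functional assay on SW480 cells (Homo sapiens) for cytotoxicity, read by MTT assay, with a stated time of 48 h; on this read-out higher numbers stand for weaker inhibition and lower numbers for stronger inhibition. Compound 1 `Cc1ccc(Cn2cc(COc3ccc4c(=O)ccoc4c3)nn2)cc1` gives 10400 nM, and compound 3 `O=c1ccoc2cc(OCc3cn(Cc4ccc(F)cc4)nn3)ccc12` gives 11200 nM; the swap of fluoro for methyl gives a 1.1-fold higher number from compound 1 to compound 3 (0.03 log units; within the scatter), so these two sit together. Compound 2 `Cc1ccccc1Cn1cc(COc2ccc3c(=O)ccoc3c2)nn1` reaches only a limit of this assay, > 100000 nM, namely (the limit of > 100000 nM in this assay, at which 1 of the 3 values shown sits). Replacing a 4-methylphenyl with a 2-methylphenyl gives an at least 9.6-fold higher number from compound 1 to compound 2 (0.98 log units; beyond the scatter), and the move back to a 4-substituted ring gives an at least 8.9-fold lower number from compound 2 to compound 3 (0.95 log units; beyond the scatter).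

Compound 4 `O=c1ccoc2cc(OCc3cn(Cc4ccccc4Cl)nn3)ccc12` has not yet been measured. It differs from compound 3 by 2-chlorophenyl in place of 4-fluorophenyl on a saturated chain carbon bound to an aromatic nitrogen. This is the same kind of move as in an at least 9.6-fold higher number from compound 1 to compound 2 (0.98 log units; beyond the scatter), where a substituent left the 4-position of the benzyl ring for the 2-position, and that step was the only large one seen. Compound 4 is therefore expected to be weaker, with a 7.1-fold higher number from compound 3 to compound 4 (0.85 log units; beyond the scatter). The estimate for compound 4 is 80000 nM, ranging from 20000 nM to 300000 nM, and a limit rather than a number is quite possible.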

Compound 4, half-maximal inhibitory concentration: 23500 nM
For compound 4 the middle estimate is 3.4-fold (0.53 log units) above the measured one; the range from low to high includes it.
By their numbers in this assay, from the lowest: compounds 1 and 3 (each within the scatter of the next); then compound 4. At a limit, above all of these: compound 2.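

In this assay the 2-chlorophenyl group of compound 4 keeps a measurable value, with modest steps of a 2.1-fold higher number from compound 3 to compound 4 (0.32 log units; beyond the scatter) and a 2.3-fold higher number from compound 1 to compound 4 (0.35 log units; beyond the scatter), so a 2-substituted ring at this place need not cost as much as the 2-methylphenyl group did. The group on that ring also matters, since chloro in place of methyl gives an at least 4.2-fold lower number from compound 2 to compound 4 (0.62 log units; beyond the scatter). The value of compound 2 is a limit and not a number: the limit of > 100000 nM in this assay, at which 1 of the 4 values shown sits.

The compounds shown leave open how much of the gap comes from the halogen and how much from where it sits, which a 4-chlorophenyl or 2-fluorophenyl group at this place would help to separate. Also open, as far as these compounds go, is how a benzyl ring carrying an amine or a carboxylic acid would behave.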